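A few compounds are considered here, and "the series" means these few. Any claim that something is new, unique, unknown or untested is made for them only; others in the source may bear on it.

Compound 1 `c1ccc(-c2cccc3c2CCC3c2ncc[nH]2)nc1`: 1150 nM
Compound 2 `c1cncc(-c2cccc3c2CCC3c2ncc[nH]2)c1`: 2060 nM

In a functional assay on CHO cells for agonist activity at Alpha-1A adrenergic receptor (Homo sapiens), read by FLIPR and calcium flux (a higher number here means that more compound is needed for the effect, a lower number that less compound is needed), compound 1 gives 1150 nM, the lowest of the two numbers. Compound 2 gives 2060 nM, and the step of a 1.8-fold higher number from compound 1 to compound 2 (0.25 log units; within the scatter) stays within the scatter. Compound 3 `c1cc(-c2cn[nH]c2)c2c(c1)C(c1ncc[nH]1)CC2` differs from compound 1 in one place: 1H-pyrazol-4-yl in place of pyridin-2-yl on an aromatic carbon. For the measured compounds named here, no measured step exchanges a six-membered ring for a five-membered one here; the single known step, pyridin-2-yl to pyridin-3-yl, stayed within the scatter. Compound 3 is therefore expected to show a step of a 1.3-fold higher number from compound 1 to compound 3 (0.12 log units; within the scatter), not beyond the scatter. Compound 3 is thus estimated at 1500 nM, in a range from 500 nM to 5000 nM.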

Compound 3, half-maximal effective concentration: 14 nM
Compound 3: middle estimate off by 110-fold (2.03 log units), on the high side; measured number below the stated range.
By their numbers in this assay, from the lowest: compound 3; then compounds 1 and 2 (each within the scatter of the next).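

At this position, the kind of ring matters far more than the swap between the two pyridines suggested: in this assay, 1H-pyrazol-4-yl gives an 82-fold lower number from compound 1 to compound 3 (1.91 log units; beyond the scatter) and also a 150-fold lower number from compound 2 to compound 3 (2.17 log units; beyond the scatter). This change replaces a six-membered aromatic ring with a five-membered one and also adds 1 hydrogen-bond donor, so the two differences cannot be separated here. No available evidence gives a reason for the drop. Going by these compounds, it remains open which difference goes with the lower number. A 1-methylpyrazol-4-yl group or a simple phenyl ring at this position would be informative.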